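The source may hold more compounds than are shown below. What is called first, only, known or untested is meant among the compounds shown, and "the series" means these compounds.

Among the measured compounds shown here, in a functional assay on HeLa cells (Homo sapiens) for inhibition, with a stated time of 72 h (on this read-out higher numbers stand for an effect only at larger amounts of compound and lower numbers for an effect already at smaller amounts), compound 1 `COc1cc(CNCc2ccncc2)ccc1OCc1ccc([N+](=O)[O-])cc1` gives 440 nM and compound 2 `COc1cc(CNCc2ccncc2)ccc1OCc1ccc(Cl)cc1` gives 890 nM, the higher of the two numbers so far. Compound 3 `COc1cc(CNCc2ccncc2)ccc1OCc1ccc(Cl)cc1Cl` differs from compound 2 by chloro in place of hydrogen on an aromatic carbon, ortho to a large group and meta to a chloro group: chloro in place of hydrogen on an aromatic carbon. For the measured compounds named here, the only measured step, a 2.0-fold higher number from compound 1 to compound 2 (0.31 log units; beyond the scatter), is modest, and it exchanges one group for another rather than adding one, so it bears only loosely. A small move toward a lower number in this assay is expected, not clearly beyond the scatter, an estimated 1.4-fold lower number from compound 2 to compound 3 (0.14 log units; within the scatter). For compound 3 the expected value is 650 nM, with an estimated range of 250 nM to 1700 nM.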

Compound 3, half-maximal effective concentration: 3900 nM
Compound 3: middle estimate off by 6.0-fold (0.78 log units), on the low side; the whole stated range lies below it.
By their numbers in this assay, from the lowest: compound 1; then compound 2; then compound 3.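

In this assay, a second chloro group ortho to a large group, turning 4-chlorobenzyl into 2,4-dichlorobenzyl, raises the number rather than lowering it (a 4.4-fold higher number from compound 2 to compound 3 (0.64 log units; beyond the scatter)). This single added atom makes compound 3 the highest of the three, with the exchange of 4-nitrophenyl for 2,4-dichlorophenyl amounting to a clear loss overall (an 8.9-fold higher number from compound 1 to compound 3 (0.95 log units; beyond the scatter)). No measurement at hand explains the rise. Still open, going by these compounds, is whether a fluoro or methoxy group at this place would raise the number too, and whether the same addition would do so on the 4-nitrophenyl compound.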